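Swapping pyrrolidin-1-yl for ethyl(methyl)amino in the series

The source may hold more compounds than are shown below. What is called first, only, known or untested is meant among the compounds shown, and "the series" means these compounds.

In a functional assay on Bel-7402 cells (Homo sapiens) for antiproliferative activity, with a stated time of 72 h (on this read-out higher numbers stand for weaker inhibition and lower numbers for stronger inhibition), compound 1 (`COc1cc(OC)c(C(=O)/C=C/c2ccccc2Cl)c(O)c1CN1CCCC1`) gives 6800 nM. That is the second highest of three numbers, with compound 2 (`COc1cc(OC)c(C(=O)/C=C/c2ccccc2Cl)c(O)c1CN1CCCCC1`) at 3100 nM and compound 3 (`COc1cc(O)c2c(=O)cc(-c3ccccc3Cl)oc2c1CN1CCCCC1`) much higher at 118000 nM. Compound 4 (`CCN(C)Cc1c(OC)cc(OC)c(C(=O)/C=C/c2ccccc2Cl)c1O`) has not yet been measured. It differs from compound 1 by ethyl(methyl)amino in place of pyrrolidin-1-yl on a saturated chain carbon bound to an aromatic carbon.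

Among the measured compounds shown here, one measured step bears on this place: a 2.2-fold lower number from compound 1 to compound 2 (0.34 log units; beyond the scatter), a modest change on exchanging pyrrolidin-1-yl for piperidin-1-yl. For the measured compounds named here, no measured step connects compound 3 to the other compounds, so it offers no guide here. On the strength of that one modest step, no step beyond the scatter is expected in this assay. The expected step is a 1.4-fold lower number from compound 1 to compound 4 (0.13 log units; within the scatter), and its direction is uncertain. Compound 4 is estimated at 5000 nM, with an expected range of 2000 nM to 12000 nM.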

Compound 4, half-maximal inhibitory concentration: 23300 nM
Estimate against measurement, compound 4: 4.7-fold (0.67 log units) below; the measured number lies above the stated range.
By their numbers in this assay, from the lowest: compound 2; then compound 1; then compound 4; then compound 3.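

In this assay the amine on this saturated chain carbon bound to an aromatic carbon matters beyond ring size: ethyl(methyl)amino gives a 3.4-fold higher number from compound 1 to compound 4 (0.53 log units; beyond the scatter) and a 7.5-fold higher number from compound 2 to compound 4 (0.88 log units; beyond the scatter) on the same core. Among the compounds shown here, the earlier step, a 2.2-fold lower number from compound 1 to compound 2 (0.34 log units; beyond the scatter) for piperidin-1-yl in place of pyrrolidin-1-yl, compared only two rings and gave no view of an amine without a ring. Both ring amines now give lower numbers than the open-chain amine, and none of these three compounds goes against that.

These compounds do not separate the loss of the ring from the drop in heavy atoms. A diethylamino group would test a longer open chain at this place, and a morpholin-4-yl group a ring with a further hetero atom. No measurement at hand accounts for the difference.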